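This account rests on a few compounds, and the source may have more. Where it says the series, first, only, none or still open, it means among the compounds named here.

Working notes on the thiazolyl amide series.

Three compounds have numbers in an ADME assay on microsomes from liver (Homo sapiens) for metabolic stability, read by LC-MS, using NADPH, tested at 1 uM; a lower number here means slower removal, a higher number faster removal of the compound. Compound 1 `Cc1cnc(NC(=O)NCCOc2ccc(Cl)c(C)c2)s1` gives 105 mL.min-1.g-1. Compound 2 `N#Cc1cnc(NC(=O)CCCOc2cccc(C(F)(F)F)c2)s1` gives 22 mL.min-1.g-1. Compound 3 `Cc1cnc(NC(=O)CCCOc2cccc(Cl)n2)s1` gives 250 mL.min-1.g-1. On these numbers compound 2 stands lowest of the three; the nearest number is that of compound 1, and the furthest is that of compound 3, both gaps lying beyond the scatter of the assay. None of the three pairs differs in only one place, so no single step can be read from them.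

Compound 4 `N#Cc1cnc(NC(=O)CCCOc2ccccc2)s1` has not yet been measured. It differs from compound 2 in one place: hydrogen in place of trifluoromethyl on an aromatic carbon.

Within the data shown here, no pair in the measured set isolates this change. The step is expected to be moderate and upward, since compound 1 at 105 mL.min-1.g-1 and compound 3 at 250 mL.min-1.g-1 show that other members of the series without a trifluoromethyl sit higher. Compound 4 is therefore estimated at 45 mL.min-1.g-1, within 18 mL.min-1.g-1 to 110 mL.min-1.g-1, an expected step of a 2.0-fold higher number from compound 2 to compound 4 (0.31 log units; beyond the scatter).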

Compound 4, intrinsic clearance in microsomes: 198 mL.min-1.g-1
Beside the measured number, compound 4's estimate is 4.4-fold (0.64 log units) below it, and the stated range ends below it.
By their numbers in this assay, from the lowest: compound 2; then compounds 1, 4 and 3 (each within the scatter of the next, the first and the last beyond it).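

In this assay, the series now has its first comparison that differs in one place: hydrogen in place of trifluoromethyl on the aromatic carbon gives a 9.0-fold higher number from compound 2 to compound 4 (0.95 log units; beyond the scatter). This step is beyond the scatter, and compound 4 keeps the nitrile, the amide and the chain of compound 2, so those parts alone do not hold the number at the level of compound 2. Nothing available here gives a reason for the size of this step.

Going by these compounds, whether the step is particular to trifluoromethyl stays open, as a chlorine, a methyl or a methoxy on the same aromatic carbon would show where such groups fall relative to hydrogen and trifluoromethyl. Also open, on these data alone, is whether the same change gives a step of similar size with a methyl in place of the nitrile on the core.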